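Compound 4 and a Piperazine Swap in a Cytotoxicity Series

The source may report more compounds than this note shows. Statements on the series, on what has been measured and on what is new or still open speak of the compounds shown alone.

Compound 1 `O=C(NCCCNc1c(C(=O)NCc2ccc(F)cc2)nc(Br)c2cccnc12)c1ccccc1`: > 20000 nM (a limit)
Compound 2 `C[C@H](Nc1c(C(=O)NCc2ccc(F)cc2)nc(Br)c2cccnc12)c1ccccc1`: > 20000 nM (a limit)
Compound 3 `O=C(NCc1ccc(F)cc1)c1nc(Br)c2cccnc2c1N1CCNCC1`: 8000 nM

All three results come from a functional assay on MDA-MB-435 cells (Homo sapiens) for cytotoxicity, read by MTT assay, with a stated time of 72 h; on this read-out lower numbers stand for stronger inhibition and higher numbers for weaker inhibition. Going by the values given here, compound 3 is the only one with a true number, 8000 nM. The other two results are captured by the limit of > 20000 nM in this assay, at which 2 of the 3 values shown sit.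

Among the compounds with values here, the one measured step at this place is an at least 2.5-fold lower number from compound 2 to compound 3 (0.39 log units; beyond the scatter), with piperazin-1-yl in place of (1-phenylethyl)amino on an aromatic carbon. On these data alone, its true size is unknown, since it starts from a limit, but it shows that a change here can move the number in this assay.

Compound 4 `NCCCCCCNc1c(C(=O)NCc2ccc(F)cc2)nc(Br)c2cccnc12` has (6-aminohexyl)amino in place of piperazin-1-yl on an aromatic carbon. Within the data shown here, no measured step covers this exact exchange. Compound 1 also has an open chain at this place, and its result is only a limit, > 20000 nM. That points towards a weaker result, yet it cannot fix a size, so the estimate stays anchored on compound 3 at 8000 nM. The expected change is a 1.3-fold lower number from compound 3 to compound 4 (0.12 log units; within the scatter), with no shift beyond the scatter expected. Compound 4 is estimated at 6000 nM, with an expected range from 1500 nM to 20000 nM.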

Compound 4, half-maximal inhibitory concentration: 6000 nM
Compound 4: the middle estimate sits on the measured number at the digits printed; the range from low to high includes it.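

The result shows that an open chain at this place does not by itself leave the number at the limit. In this assay, with 6-aminohexyl in place of 1-phenylethyl on the nitrogen, the change gives an at least 3.3-fold lower number from compound 2 to compound 4 (0.52 log units; beyond the scatter), and with 3-aminopropyl in place of benzamido on the chain it gives an at least 3.3-fold lower number from compound 1 to compound 4 (0.52 log units; beyond the scatter). The ring of piperazin-1-yl also proves unnecessary for a measurable number, since (6-aminohexyl)amino in its place gives a 1.3-fold lower number from compound 3 to compound 4 (0.12 log units; within the scatter). The two steps from the open-chain and branched compounds have no fixed upper size, because each starts from a limit: the limit of > 20000 nM in this assay, at which 2 of the 4 values shown sit.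

The compounds shown leave open whether the length of the chain or the amine at its end carries the result, a question that a shorter aminoalkyl chain, or a hexyl chain ending in a carboxylic acid, would address. They also leave open whether any group at this place, such as a piperazine bearing a substituent on its second nitrogen, moves the number beyond the scatter from the level of compound 3 and compound 4.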